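Amide nitrogen substituent series: step to compound 4

The source may hold more compounds than are shown below. What is called first, only, known or untested is meant among the compounds shown, and "the series" means these compounds.

Compound 3 `CNC(=O)c1cc(-c2ccc(NS(=O)(=O)c3cccc(Cl)c3Cl)cc2)nc2[nH]ncc12` gives 4 nM in an assay for inhibition of serine/threonine-protein kinase Sgk1 (Homo sapiens), with stated times of 30 min and 60 min, in the presence of a further agent that is not named here (on this read-out lower numbers stand for stronger inhibition and higher numbers for weaker inhibition), and stands level with compound 1 `CC(C)N1CC[C@H](NC(=O)c2cc(-c3ccc(NS(=O)(=O)c4cccc(Cl)c4Cl)cc3)nc3[nH]ncc23)C1` at the digits shown, which gives 4 nM; compound 2 `NC(=O)c1cc(-c2ccc(NS(=O)(=O)c3cccc(Cl)c3Cl)cc2)nc2[nH]ncc12` gives 1 nM, the lowest number of the three. The steps of a 4.0-fold lower number from compound 1 to compound 2 (0.60 log units; beyond the scatter) and a 4.0-fold higher number from compound 2 to compound 3 (0.60 log units; beyond the scatter) are beyond the scatter, while no change at the digits printed from compound 1 to compound 3 (within the scatter) is within it.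

Compound 4 `CC(C)NC(=O)c1cc(-c2ccc(NS(=O)(=O)c3cccc(Cl)c3Cl)cc2)nc2[nH]ncc12` differs from compound 3 by isopropyl in place of methyl on an amide-type nitrogen. Within the data shown here, two measured steps bear on this: a 4.0-fold higher number from compound 2 to compound 3 (0.60 log units; beyond the scatter), where the amide nitrogen first gained a substituent, and no change at the digits printed from compound 1 to compound 3 (within the scatter), where a much larger group in place of methyl left the number unchanged. Growth beyond methyl carried no cost in the one comparison available, so for compound 4 a step of a 1.3-fold higher number from compound 3 to compound 4 (0.10 log units; within the scatter) in this assay is expected, within the scatter. Compound 4 is estimated at 5 nM, with a range of 2 nM to 12 nM.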

Compound 4, half-maximal inhibitory concentration: 68 nM
Beside the measured number, compound 4's estimate is 14-fold (1.13 log units) below it; measured number outside the range, above it.
By their numbers in this assay, from the lowest: compound 2; then compounds 1 and 3 (each within the scatter of the next); then compound 4.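

In this assay the amide nitrogen does not tolerate every group: isopropyl in place of methyl gives a 17-fold higher number from compound 3 to compound 4 (1.23 log units; beyond the scatter) and isopropyl in place of hydrogen gives a 68-fold higher number from compound 2 to compound 4 (1.83 log units; beyond the scatter) on the same core. Size alone does not order these groups, as isopropyl in place of 1-isopropylpyrrolidin-3-yl gives a 17-fold higher number from compound 1 to compound 4 (1.23 log units; beyond the scatter) even though compound 1 carries the larger group, which goes against any simple rise in the number with substituent growth.

Open, going by these compounds, is where ethyl, cyclopropyl or a longer chain ending in an amine would fall on this nitrogen. Nothing at hand accounts for the high number of compound 4.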